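The source may report more compounds than this note shows. Statements on the series, on what has been measured and on what is new or still open speak of the compounds shown alone.

Compound 1 `Oc1cccc(-c2cc(-c3ccsc3)cc(-c3cccc(O)c3)n2)c1`, 1630 nM in a functional assay on HCT-15 cells (Homo sapiens) for cytotoxicity, read by CCK-8 assay; on this read-out higher numbers stand for weaker inhibition and lower numbers for stronger inhibition; compound 2 `Oc1cccc(-c2cc(-c3ccoc3)cc(-c3cccc(O)c3)n2)c1`, 1020 nM; compound 3 `Oc1cccc(-c2cc(-c3cccnc3)cc(-c3ccccc3O)n2)c1`, 8280 nM.

Among these three, compound 3 gives the highest number, with compound 1 and compound 2 both well beyond the scatter below it. Among the compounds with values here, the only single-point step measured so far, a 1.6-fold lower number from compound 1 to compound 2 (0.20 log units; within the scatter), concerns a different place and does not touch the change at hand. Compound 4 `Oc1cccc(-c2cc(-c3cccnc3)cc(-c3cccc(O)c3)n2)c1` differs from compound 3 by 3-hydroxyphenyl in place of 2-hydroxyphenyl on an aromatic carbon, which makes it carry the same hydroxyphenyl pattern as compound 1 and compound 2. Those two give far lower numbers than compound 3, so compound 4 is expected to move toward them, a step of roughly a 4.6-fold lower number from compound 3 to compound 4 (0.66 log units; beyond the scatter). Compound 4 is therefore estimated at about 1800 nM, between 600 nM and 5500 nM.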

Compound 4, half-maximal inhibitory concentration: > 50000 nM
Compound 4 was reported as a limit; the forecaster's own chance of this, stated with the estimate: 3%; middle value at least 27-fold (1.44 log units) away from the limit.
By their numbers in this assay, from the lowest: compounds 2 and 1 (each within the scatter of the next); then compound 3. At a limit, above all of these: compound 4.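

Compound 4 is reported only as a limit in this assay, > 50000 nM. At this place next to the ring nitrogen, the two hydroxyphenyl groups are not interchangeable when pyridin-3-yl is present, with 3-hydroxyphenyl in place of 2-hydroxyphenyl giving an at least 6.0-fold higher number from compound 3 to compound 4 (0.78 log units; beyond the scatter). The other aromatic substituent also matters more than the earlier furan-3-yl and thiophen-3-yl pair suggested, with an at least 49-fold higher number from compound 2 to compound 4 (1.69 log units; beyond the scatter) and an at least 30-fold higher number from compound 1 to compound 4 (1.48 log units; beyond the scatter).

The compounds shown leave open how far compound 4 lies past its limit. They also leave open how a methoxyphenyl or an aminophenyl would behave at this place.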